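The source may report more compounds than this note shows. Statements on the series, on what has been measured and on what is new or still open speak of the compounds shown alone.

Compound 1 `CN(C)C12CCN(CCN3CCCC3)C(C(c3ccccc3)C1)C(c1ccccc1)C2` and compound 2 `c1ccc(C2CC3(N4CCCC4)CCN(CCN4CCCC4)C2C(c2ccccc2)C3)cc1` share one core and differ only in the group on a saturated ring carbon. In an ADME assay on L6 cells (Rattus norvegicus) for cytotoxicity (on this read-out higher numbers stand for weaker inhibition and lower numbers for stronger inhibition), compound 1 gives 80400 nM and compound 2 gives 58200 nM. These two numbers lie within the usual scatter of each other, so compound 2 stands level with compound 1 on the evidence so far.

Compound 3 `c1ccc(C2CC3(N4CCCCC4)CCN(CCN4CCCC4)C2C(c2ccccc2)C3)cc1` keeps the core of compound 2 and alters that same group: piperidin-1-yl in place of pyrrolidin-1-yl on a saturated ring carbon. In words, piperidin-1-yl stands in place of pyrrolidin-1-yl on a saturated ring carbon.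

Among the measured compounds shown here, only one measured step bears on this change. It is a 1.4-fold lower number from compound 1 to compound 2 (0.14 log units; within the scatter), where pyrrolidin-1-yl took the place of dimethylamino on that carbon, and it stayed within the scatter. For the measured compounds named here, a single step is thin evidence, and no compound carrying piperidin-1-yl has yet been measured. The swap is therefore expected to produce no step beyond the scatter in this assay, and no firm direction can be given. The expected change is a 1.1-fold lower number from compound 2 to compound 3 (0.02 log units; within the scatter). For compound 3 the estimated value is 55000 nM, with an expected range from 25000 nM to 110000 nM.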

Compound 3, half-maximal inhibitory concentration: 156000 nM
Compound 3: the middle estimate sits 2.8-fold (0.45 log units) below what was measured; measured number above the stated range.
By their numbers in this assay, from the lowest: compounds 2, 1 and 3 (each within the scatter of the next, the first and the last beyond it).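

In this assay, among the compounds shown here, the change from the five-membered pyrrolidin-1-yl to the six-membered piperidin-1-yl on this saturated ring carbon gives a 2.7-fold higher number from compound 2 to compound 3 (0.43 log units; beyond the scatter) and so produces the first step at this position that clears the scatter, a modest one toward weaker inhibition. Set against the open-chain dimethylamino group, the same piperidin-1-yl gives a 1.9-fold higher number from compound 1 to compound 3 (0.29 log units; within the scatter) and stays within the scatter, so compound 1 stands level with both ring-bearing compounds, and only the two rings differ from each other beyond the scatter. Nothing measured here explains why the larger ring goes with the higher number.

For the compounds shown here, with only three groups at this carbon, it remains open whether the trend from the five-membered to the six-membered ring would continue to a seven-membered azepan-1-yl, or what a ring holding a second hetero atom, such as morpholin-4-yl, would do. A small primary amine on the same carbon would also show whether a group carrying a hydrogen-bond donor leaves the number within the scatter of these three or moves it well beyond.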